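Swapping methoxy for trifluoromethyl on compound 3

The compounds below may be only part of what the source reports. "The series", "measured", "known", "first", "only" and "open" are said of these compounds alone.

Values measured in an ADME assay on THP-1 cells (Homo sapiens) for cytotoxicity, read by flow cytometry and propidium iodide staining, with a stated time of 72 h (on this read-out higher numbers stand for weaker inhibition and lower numbers for stronger inhibition), follow

compound 1 `Nc1ccc2oc(-c3ccc(C(F)(F)F)cc3)cc(=O)c2c1` gives 1900 nM
compound 2 `CC(=O)Nc1ccc2oc(-c3ccc(C(F)(F)F)cc3)c(O)c(=O)c2c1` gives > 50000 nM as a limit of the assay, not a number
compound 3 `COc1ccc(-c2oc3ccc(N)cc3c(=O)c2O)cc1` gives 29000 nM

Of the two exact numbers, compound 3 has the higher one at 29000 nM, and its gap down to compound 1 lies beyond the usual scatter. Compound 4 `Nc1ccc2oc(-c3ccc(C(F)(F)F)cc3)c(O)c(=O)c2c1` has not been measured yet. It keeps the frame of compound 3 but carries trifluoromethyl in place of methoxy on an aromatic carbon, para to a large group (trifluoromethyl in place of methoxy on an aromatic carbon). For the measured compounds named here, no measured pair isolates this one change, so any forecast is loose. Compound 1 also carries trifluoromethyl and gives 1900 nM, a lower number, which pulls the expectation downward. Compound 2 carries the same group and goes against that pull, since its value is a limit. The expected step is therefore modest and runs towards a lower number, a 2.4-fold lower number from compound 3 to compound 4 (0.38 log units; beyond the scatter), and it may end up close to the scatter. For compound 4 the estimated value is 12000 nM, with an expected range from 3000 nM to 45000 nM.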

Compound 4, half-maximal inhibitory concentration: > 125000 nM
Compound 4 was reported as a limit; the forecaster's own chance of this, stated with the estimate: 15%; middle value at least 10-fold (1.01 log units) away from the limit.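

In this assay, trifluoromethyl in place of methoxy on an aromatic carbon, para to a large group, gives an at least 4.3-fold higher number from compound 3 to compound 4 (0.63 log units; beyond the scatter), so this swap moves the number up, not down towards the value of compound 1. With trifluoromethyl kept in place, hydroxy in place of hydrogen on an aromatic carbon gives an at least 65-fold higher number from compound 1 to compound 4 (1.81 log units; beyond the scatter), the larger of the two readable steps. The value of compound 4 is a limit of the assay, not a number: the limit of > 125000 nM in this assay, at which 1 of the 4 values shown sits.

The step between compound 2 and compound 4 cannot be read, since both values are limits. The compounds shown also leave open how a chlorine atom or a nitrile at this same place would compare with methoxy and trifluoromethyl, and how far the true value of compound 4 lies from its limit.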